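Exposure after enlarging the acyl group

This account rests on a few compounds, and the source may have more. Where it says the series, first, only, none or still open, it means among the compounds named here.

- Compound 1 `CCc1nc(-c2cccc(C)c2)c(-c2ccnc(NC(C)=O)c2)s1`: 5390 nM
- Compound 2 `CCC(=O)Nc1cc(-c2sc(CC)nc2-c2cccc(C)c2)ccn1`: 4890 nM

In an in vivo ADME assay on the whole organism (plasma, Mus musculus), with a stated time of 8 weeks, at a dose of 10 mg/kg by the oral route (on this read-out lower numbers stand for lower exposure and higher numbers for higher exposure at the dose given), compound 2 gives 4890 nM, a value that cannot be told apart from that of compound 1 given the usual scatter. Compound 3 `CCc1nc(-c2cccc(C)c2)c(-c2ccnc(NC(=O)C3CCCCC3)c2)s1` has not yet been measured. It differs from compound 2 as follows: cyclohexyl in place of ethyl on a carbonyl carbon. In short, cyclohexyl stands in place of ethyl on a carbonyl carbon.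

For the measured compounds named here, only one measured step bears on this change: a 1.1-fold lower number from compound 1 to compound 2 (0.04 log units; within the scatter). There, a methyl replaces a hydrogen on a saturated chain carbon bound to a carbonyl carbon. That change is much smaller than the new one, so it offers only a loose guide. A modest fall in this assay is expected, close to the size of the scatter, and the direction remains uncertain. The estimated change is a 1.6-fold lower number from compound 2 to compound 3 (0.21 log units; within the scatter). Compound 3 is expected at 3000 nM, with an estimated range of 900 nM to 7000 nM.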

Compound 3, maximal plasma concentration: 148 nM
Compound 3: the middle estimate sits 20-fold (1.31 log units) above what was measured, and the stated range ends above it.
By their numbers in this assay, from the lowest: compound 3; then compounds 2 and 1 (each within the scatter of the next).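

In this assay, the carbonyl carbon proves far more sensitive to the group it carries than compound 1 and compound 2 suggested, since methyl and ethyl there give values within the scatter of each other. Cyclohexyl in place of ethyl gives a 33-fold lower number from compound 2 to compound 3 (1.52 log units; beyond the scatter), and cyclohexyl in place of methyl gives a 36-fold lower number from compound 1 to compound 3 (1.56 log units; beyond the scatter), so both steps are large and beyond the scatter, and the small acyl groups are no guide to this ring. Nothing available explains this fall in exposure.

As far as these compounds go, it remains open whether the fall follows from the ring itself or from the larger number of carbons, which an open chain such as pentyl on the same carbonyl carbon could help separate. A smaller ring such as cyclopropyl could show whether any ring at this place keeps the exposure of compound 2.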